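This account rests on a few compounds, and the source may have more. Where it says the series, first, only, none or still open, it means among the compounds named here.

Series notes. In a functional assay on SK-HEP1 cells (Homo sapiens) for cytotoxicity, read by sulforhodamine B assay, with a stated time of 72 h (a lower number here means a stronger inhibitor, a higher number a weaker inhibitor), compound 1 `CCS(=O)(=O)Nc1cc(-c2ccc3ncnc(Nc4ccc(OC)cc4)c3c2)cnc1OC` gives 1610 nM, compound 2 `CCS(=O)(=O)Nc1cc(-c2ccc3ncnc(Nc4cccc(C(=O)OC)c4)c3c2)cnc1OC` gives 2400 nM and compound 3 `CCS(=O)(=O)Nc1cc(-c2ccc3ncnc(Nc4ccc(Cl)c(C(=O)OC)c4)c3c2)cnc1OC` gives 7060 nM. Compound 3 stands highest of the three numbers; its nearest neighbour is compound 2, a 2.9-fold higher number from compound 2 to compound 3 (0.47 log units; beyond the scatter), and its furthest is compound 1, a 4.4-fold higher number from compound 1 to compound 3 (0.64 log units; beyond the scatter). Between the two lower compounds the change is small, a 1.5-fold higher number from compound 1 to compound 2 (0.17 log units; within the scatter).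

Compound 4 `CCS(=O)(=O)Nc1cc(-c2ccc3ncnc(Nc4ccc(OC)nc4)c3c2)cnc1OC` is not yet measured. Its change from compound 3 reads: 6-methoxypyridin-3-yl in place of 4-chloro-3-(methoxycarbonyl)phenyl on a nitrogen on an aromatic ring. Among the measured compounds shown here, two measured steps bear on this. Taking the 4-chloro-3-(methoxycarbonyl)phenyl off the nitrogen and returning to a methoxy-bearing ring is the reverse of a 4.4-fold higher number from compound 1 to compound 3 (0.64 log units; beyond the scatter), and taking off the chloro alone is the reverse of a 2.9-fold higher number from compound 2 to compound 3 (0.47 log units; beyond the scatter). For the measured compounds named here, compound 4 resembles compound 1 in carrying a methoxy-bearing six-membered ring on that nitrogen, differing only in that the ring of compound 4 holds one hetero atom, for which no measured pair exists in this set. The expectation in this assay is therefore a downward step of a size near the reverse of a 4.4-fold higher number from compound 1 to compound 3 (0.64 log units; beyond the scatter), namely a 3.5-fold lower number from compound 3 to compound 4 (0.55 log units; beyond the scatter), with the ring nitrogen adding uncertainty. Compound 4 is thus estimated at 2000 nM, within a range of 900 nM to 4500 nM.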

Compound 4, half-maximal inhibitory concentration: 3440 nM
Estimate against measurement, compound 4: 1.7-fold (0.24 log units) below; the measured number falls inside the stated range.
By their numbers in this assay, from the lowest: compounds 1, 2 and 4 (each within the scatter of the next, the first and the last beyond it); then compound 3.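

At this nitrogen on an aromatic ring, this assay now has its first reading for a ring hetero atom with the methoxy retained: 6-methoxypyridin-3-yl in place of 4-methoxyphenyl gives a 2.1-fold higher number from compound 1 to compound 4 (0.33 log units; beyond the scatter), a modest step. Against the methoxycarbonyl-bearing rings the same group reads differently: in place of 3-(methoxycarbonyl)phenyl it gives a 1.4-fold higher number from compound 2 to compound 4 (0.16 log units; within the scatter), so those two groups cannot be ordered here, while in place of 4-chloro-3-(methoxycarbonyl)phenyl it gives a 2.1-fold lower number from compound 3 to compound 4 (0.31 log units; beyond the scatter), leaving compound 3 the weakest of the four, with its steps to all the others beyond the scatter. No accompanying measurement bears on the origin of these steps.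

As far as these compounds go, the effect of the ring nitrogen rests on a single pair, so it remains open whether the step would persist with an ethoxy group, an amine or a longer chain in place of the methoxy on the pyridine ring. Also open, from the compounds shown here alone, is how a carboxylic acid or an amide would read in place of the methoxycarbonyl, with or without the chloro.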